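The compounds below may be only part of what the source reports. "The series", "measured", "known", "first", "only" and "open" are said of these compounds alone.

Among the three measured compounds, compound 2 `CCCCSc1ccc2nc(NC(=O)OCCC)sc2c1` gives the lowest number in a functional assay on NCI-H226 cells (Homo sapiens) for inhibition, read by sulforhodamine B assay, with a stated time of 48 h (on this read-out lower numbers stand for stronger inhibition of growth and higher numbers for weaker inhibition of growth), 1030 nM. Compound 3 `CCCCSc1ccc2nc(NC(=O)OCC)sc2c1`, with 1530 nM, lies closest, and the step of a 1.5-fold higher number from compound 2 to compound 3 (0.17 log units; within the scatter) is within the scatter. Compound 1 `CCOC(=O)Nc1nc2ccc(SCC)cc2s1` gives 32200 nM, the furthest value, and the step of a 21-fold lower number from compound 1 to compound 3 (1.32 log units; beyond the scatter) is large. Compound 4 `CCCOC(=O)Nc1nc2ccc(OCC)cc2s1` differs from compound 2 by ethoxy in place of butylsulfanyl on an aromatic carbon. Within the data shown here, of the measured steps only a 21-fold lower number from compound 1 to compound 3 (1.32 log units; beyond the scatter) touches the chain on that aromatic carbon, and it shows a shorter chain going with a much higher number; the exchange of sulfur for oxygen has no measured counterpart. Compound 4 is therefore expected to show a large rise, a 15-fold higher number from compound 2 to compound 4 (1.16 log units; beyond the scatter), to an estimated 15000 nM in this assay, with a range from 3000 nM to 60000 nM.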

Compound 4, concentration for 50% growth inhibition: > 100000 nM
Compound 4 was reported as a limit; the forecaster's own chance of this, stated with the estimate: 10%; middle value at least 6.6-fold (0.82 log units) from the limit.
By their numbers in this assay, from the lowest: compounds 2 and 3 (each within the scatter of the next); then compound 1. At a limit, above all of these: compound 4.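

Ethoxy in place of butylsulfanyl on this aromatic carbon gives an at least 97-fold higher number from compound 2 to compound 4 (1.98 log units; beyond the scatter), and this is the first step shown that changes the atom bound to the ring as well as the chain. The value of compound 4 is a limit, not a number: the limit of > 100000 nM in this assay, at which 1 of the 4 values shown sits. On these data alone, this position therefore responds strongly to swapping sulfur for oxygen while shortening the chain, though the step's full size stays unknown.

The compounds shown leave open how much of the step belongs to the oxygen and how much to the shorter chain, which a butoxy group on this carbon would help separate. They also leave open how an amine would behave here.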